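Methyl for Trifluoromethyl: Expected Solubility of Compound 4

The source may report more compounds than this note shows. Statements on the series, on what has been measured and on what is new or still open speak of the compounds shown alone.

Compound 1 `CCOC(=O)c1c(-c2cccs2)[nH]c2cc(OC)ccc2c1=O` gives > 100000 nM in a physicochemical assay for solubility, in phosphate buffer, at pH 7.4 (a lower number here means a less soluble compound, a higher number a more soluble compound), a limit of the assay.
Compound 2 `CCOC(=O)c1c(-c2cccc(C)c2)[nH]c2cc(OC)ccc2c1=O` gives 48000 nM in this assay.
Compound 3 `CCOC(=O)c1c(-c2cccc(C(F)(F)F)c2)[nH]c2cccc(OC)c2c1=O` gives > 100000 nM in this assay, again a limit.

Compound 3 therefore stands at the limit of > 100000 nM in this assay, at which 2 of the 3 values shown sit, so only a floor is known for it. Compound 4 `CCOC(=O)c1c(-c2cccc(C)c2)[nH]c2cccc(OC)c2c1=O` differs from it by methyl in place of trifluoromethyl on an aromatic carbon. Among the compounds with values here, no measured step changes trifluoromethyl to methyl; the only measured step, an at least 2.0-fold lower number from compound 1 to compound 2 (0.31 log units; beyond the scatter), swaps a different group, yet it shows that a 3-methylphenyl compound can sit below the limit. Compound 4 carries the same 3-methylphenyl as compound 2, so its number is expected to fall near compound 2 or at the limit. Compound 4 is estimated at 65000 nM (range 30000 nM to 130000 nM), a step of an at least 1.5-fold lower number from compound 3 to compound 4 (0.18 log units; that floor lies within the scatter) that is expected to be small or not resolved.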

Compound 4, solubility: > 100000 nM
Compound 4: no number, only a limit; the forecaster's own chance of this, stated with the estimate: 40%; at least 1.5-fold (0.18 log units) between middle value and limit.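

Compound 3 and compound 4 both give only a limit in this assay, and the step between them cannot be read. The compounds shown leave open how far past that limit each lies, and whether methyl and trifluoromethyl differ here at all.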